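Replacing the aryl group on a ring nitrogen of compound 1

The compounds below may be only part of what the source reports. "The series", "measured", "known", "first", "only" and "open" are said of these compounds alone.

Measured so far:
Compound 1, `CCCCCCCCn1cc(/C=C/C(=O)c2ccc(NC(=O)CN3CCN(c4ccccc4OC)CC3)cc2)nn1`, in a functional assay on SK-N-SH cells (Homo sapiens) for inhibition, read by MTT assay; a lower number here means a stronger inhibitor, a higher number a weaker inhibitor: 21500 nM
Compound 2, `CCCCCCCCCCn1cc(/C=C/C(=O)c2ccc(NC(=O)CN3CCN(c4ccccc4OC)CC3)cc2)nn1`, in this assay: 87600 nM

Compound 1 holds the lowest of the two numbers in this assay. For the measured compounds named here, the only measured step, a 4.1-fold higher number from compound 1 to compound 2 (0.61 log units; beyond the scatter), concerns a longer chain on the aromatic nitrogen side and is the sole comparison available.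

Compound 3, `CCCCCCCCn1cc(/C=C/C(=O)c2ccc(NC(=O)CN3CCN(c4ccc([N+](=O)[O-])cc4)CC3)cc2)nn1`, has not yet been measured in this assay. Its change from compound 1 is 4-nitrophenyl in place of 2-methoxyphenyl on an amine nitrogen in a ring. Going by the values given here, the single measured step, a 4.1-fold higher number from compound 1 to compound 2 (0.61 log units; beyond the scatter), alters a part of the molecule far from the amine nitrogen in the ring and therefore says nothing about exchanging the 2-methoxyphenyl for the 4-nitrophenyl. Among the compounds with values here, no measured step bears on this change, so there is no basis for expecting a shift in either direction beyond the scatter. The expected step, a 1.0-fold higher number from compound 1 to compound 3 (0.01 log units; within the scatter), is therefore essentially flat, with wide uncertainty. The estimate for compound 3 in this assay is 22000 nM, within a range from 6000 nM to 80000 nM.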

Compound 3, half-maximal inhibitory concentration: 51400 nM
Beside the measured number, compound 3's estimate is 2.3-fold (0.37 log units) below it, within the range that was stated.
By their numbers in this assay, from the lowest: compound 1; then compounds 3 and 2 (each within the scatter of the next).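

In this assay, putting 4-nitrophenyl in place of 2-methoxyphenyl on the amine nitrogen in the ring gives a 2.4-fold higher number from compound 1 to compound 3 (0.38 log units; beyond the scatter), which shows that the number responds to the aryl group at this position, a part of the molecule the earlier pair left unchanged. Alongside a 4.1-fold higher number from compound 1 to compound 2 (0.61 log units; beyond the scatter), this means that each of the two single changes from compound 1 raises the number, at opposite ends of the molecule, and that compound 1 keeps the lowest value of the set. The exchange alters both the substituent and its place on the phenyl ring, so the two contributions cannot be separated, and no measurement at hand accounts for the rise.

A plain phenyl, a 4-methoxyphenyl or a 2-nitrophenyl on the same nitrogen would show whether the substituent or its place on the ring matters more. Going by these compounds, it also remains open whether a shorter chain such as hexyl on the aromatic nitrogen would lower the number, and whether the decyl chain and the 4-nitrophenyl group would act independently in one molecule.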